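A few compounds are considered here, and "the series" means these few. Any claim that something is new, unique, unknown or untested is made for them only; others in the source may bear on it.

Of the compounds shown here, three built on one shared core have been tested in a functional assay on MCF7 cells (Homo sapiens) for inhibition, read by sulforhodamine B assay, with a stated time of 48 h; a lower number here means a stronger inhibitor of growth, a higher number a weaker inhibitor of growth. Compound 1 `COc1cc(C)cc(-c2nn(CC#N)cc2-c2ccc(-c3cccc(C(C)=O)c3)nc2)c1` gives 15900 nM. Compound 2 `Cc1cc(O)cc(-c2nn(CC#N)cc2-c2ccnc(-c3ccc(Oc4ccccc4)cc3)c2)c1` gives 5480 nM. Compound 3 `COc1cc(C)cc(-c2nn(CC#N)cc2-c2ccnc(-c3ccc(N(C)C)cc3)c2)c1` gives 22700 nM, the highest of the three numbers shown; compound 1 lies within the scatter of it, while compound 2 sits beyond the scatter at a lower number, though compound 2 differs from compound 3 in two places, so what each change contributes cannot be separated. Compound 4 `Cc1cc(O)cc(-c2nn(CC#N)cc2-c2ccnc(-c3ccc(N(C)C)cc3)c2)c1` is not yet measured. It differs from compound 3 by hydrogen in place of methyl on an oxygen on an aromatic ring. Among the measured compounds shown here, no measured pair isolates this change. In this assay compound 4 is expected to give 12000 nM, between 4000 nM and 36000 nM. The step is expected to come out as a 1.9-fold lower number from compound 3 to compound 4 (0.28 log units; within the scatter), modest and, if anything, toward a lower number.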

Compound 4, concentration for total growth inhibition: 13900 nM
Compound 4: middle estimate off by 1.2-fold (0.06 log units), on the low side, and the stated range covers the measured number.
By their numbers in this assay, from the lowest: compound 2; then compounds 4, 1 and 3 (each within the scatter of the next).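

Hydrogen in place of methyl on an oxygen on an aromatic ring, now seen alone, gives in this assay a 1.6-fold lower number from compound 3 to compound 4 (0.21 log units; within the scatter), so methoxy to hydroxy leaves the number within the scatter. Dimethylamino in place of phenoxy on an aromatic carbon gives a 2.5-fold higher number from compound 2 to compound 4 (0.40 log units; beyond the scatter), and of these two single changes only this one lies beyond the scatter. Nothing available explains either step.

Going by these compounds, whether a larger group on that oxygen, such as ethoxy, or an amine in place of the hydroxy would move the number stays open. Also open, on these data alone, is whether methoxy and hydroxy stay level when phenoxy replaces dimethylamino.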